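This account rests on a few compounds, and the source may have more. Where it says the series, first, only, none or still open, it means among the compounds named here.

Measured compounds:
compound 1, `COc1cc2ncnc(Nc3cc(F)ccc3Br)c2c(OC)c1OC`, 60.7%
compound 2, `COc1cc2ncnc(Nc3cc(C(F)(F)F)ccc3Br)c2c(OC)c1OC`, 23.2%

In a functional assay on BGC-823 cells (Homo sapiens) for inhibition, read by MTT assay, with a stated time of 72 h, tested at 10 uM (a lower number here means less inhibition of growth, a higher number more inhibition of growth at the concentration tested), compound 1 gives 60.7%, the highest of the two numbers; its nearest neighbour is compound 2, which in this assay gives 23.2%. Among the measured compounds shown here, the one measured step between them, a number 37.5 percentage points lower from compound 1 to compound 2 (beyond the scatter), arises from a single change on the aniline ring and shows that this ring is sensitive to substitution.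

Compound 3, `COc1cc2ncnc(Nc3ccc(Br)cc3)c2c(OC)c1OC`, has not yet been measured in this assay. It differs from compound 1 by 4-bromophenyl in place of 2-bromo-5-fluorophenyl on a nitrogen on an aromatic ring. For the measured compounds named here, no measured step changes the aniline in this way, so the only guide is that compound 2 lost much of the inhibition of compound 1 after a change on the same ring. The expected step from compound 1 to compound 3 is therefore a number 15.7 percentage points lower from compound 1 to compound 3 (beyond the scatter), a moderate fall, with a range wide enough to include no change beyond the scatter. Compound 3 is estimated at 45%, between 15% and 75%.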

Compound 3, percent growth inhibition at one concentration: 32.6%
Compound 3: middle estimate off by 12.4 percentage points, on the high side; the range from low to high includes it.
By their numbers in this assay, from the lowest: compounds 2 and 3 (each within the scatter of the next); then compound 1.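

The step of a number 28.1 percentage points lower from compound 1 to compound 3 (beyond the scatter) in this assay shows that the inhibition of compound 1 also falls beyond the scatter with a change that adds no new substituent type, so the earlier loss with trifluoromethyl was not the only way to lose it; among the three compounds, compound 1 now stands clearly highest, with both of its steps beyond the scatter. Among the compounds shown here, this change differs in kind from the earlier one, since 4-bromophenyl replaces 2-bromo-5-fluorophenyl on the nitrogen, so the fluoro group is gone and the bromo group sits elsewhere on the ring, and the single step cannot divide the fall between these two differences. Nothing available on these compounds explains the fall.

The compounds shown leave open which of the two differences carries the step, a question that a 2-bromophenyl or a 3-fluorophenyl group on the same nitrogen would help to settle. They also leave open how this ring would respond to a quite different substituent, such as an amine or a carboxylic acid, in place of the fluoro group of compound 1.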